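Removing a Trifluoromethyl Group from a Pyrazole Amide Series

The source may hold more compounds than are shown below. What is called first, only, known or untested is meant among the compounds shown, and "the series" means these compounds.

Compound 1 `O=C(Nc1cccc(-n2cc(-c3ccncc3)c(-c3ccc(Cl)c(O)c3)n2)c1)Nc1ccc(Cl)c(Cl)c1`: 1340 nM
Compound 2 `COc1cc(-c2nn(-c3cccc(NC(=O)c4cccc(C(F)(F)F)c4)c3)cc2-c2ccncc2)ccc1Cl`: 895 nM
Compound 3 `COc1cc(-c2nn(-c3cccc(NC(=O)Nc4cccc(C(F)(F)F)c4)c3)cc2-c2ccncc2)ccc1Cl`: 890 nM

Of the compounds shown here, three sharing one core have been tested in a functional assay on SF-539 cells (Homo sapiens) for inhibition, read by sulforhodamine B assay, with a stated time of 48 h; a higher number here means a weaker inhibitor of growth, a lower number a stronger inhibitor of growth. Compound 3 gives the lowest of the three numbers, but compound 2 sits within the scatter of it, and so does compound 1; none of the three can be called stronger or weaker than another.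

Compound 4 `COc1cc(-c2nn(-c3cccc(NC(=O)c4ccccc4)c3)cc2-c2ccncc2)ccc1Cl` has not been measured. It differs from compound 3 in a single place: phenyl in place of (3-(trifluoromethyl)phenyl)amino on a carbonyl carbon. Part of this change has a precedent. Among the measured compounds shown here, the one measured step, a 1.0-fold lower number from compound 2 to compound 3 (0.00 log units; within the scatter), shows that putting an amino-type nitrogen between the carbonyl carbon and the trifluoromethylphenyl ring, or taking it out again, moved nothing beyond the scatter. For the measured compounds named here, the other part, the loss of the trifluoromethyl itself, has no measured pair behind it; compounds 1, 2 and 3 all keep a substituted ring at this end. Without evidence for that loss, the expectation is a small weakening at most, roughly a 2.0-fold higher number from compound 3 to compound 4 (0.31 log units; beyond the scatter), with a wide range to reflect the missing precedent. Compound 4 is therefore estimated at 1800 nM, somewhere between 600 nM and 5500 nM.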

Compound 4, concentration for 50% growth inhibition: 387 nM
Compound 4: middle estimate off by 4.7-fold (0.67 log units), on the high side; the measured number lies below the stated range.
By their numbers in this assay, from the lowest: compound 4; then compounds 3, 2 and 1 (each within the scatter of the next).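

In this assay, replacing trifluoromethyl with hydrogen on an aromatic carbon gives a 2.3-fold lower number from compound 2 to compound 4 (0.36 log units; beyond the scatter), so this position responds to a change of group, whereas the earlier step on the carbonyl carbon, a 1.0-fold lower number from compound 2 to compound 3 (0.00 log units; within the scatter), showed no difference beyond the scatter. Putting phenyl in place of (3-(trifluoromethyl)phenyl)amino on the carbonyl carbon gives a 2.3-fold lower number from compound 3 to compound 4 (0.36 log units; beyond the scatter), a step of the same size, which fits the reading that losing the trifluoromethyl matters here and that the amino nitrogen makes little difference. Nothing available explains why the number falls when the trifluoromethyl goes.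

The compounds shown leave open whether a methyl, a methoxy or a single fluorine on this aromatic carbon would give a number like that of compound 4 or one like that of compound 2. They also leave open whether removing the trifluoromethyl from compound 3 while keeping its amino nitrogen would produce a similar step, and so whether the gain holds with that nitrogen in place.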